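A few compounds are considered here, and "the series" means these few. Any claim that something is new, unique, unknown or untested is made for them only; others in the source may bear on it.

Of the compounds shown here, two carry numbers so far. Compound 1 `CCC(=O)Oc1cccc2ccc(/C=C/c3ccccc3[N+](=O)[O-])nc12` gives 10500 nM in a functional assay on U-87MG ATCC cells for inhibition, with U-87 MG (Homo sapiens) as the target, read by sulforhodamine B assay, with a stated time of 72 h (on this read-out higher numbers stand for an effect only at larger amounts of compound and lower numbers for an effect already at smaller amounts), on this read-out. Compound 2 `CCCCc1ccc(C(=O)/C=C/c2ccc([N+](=O)[O-])o2)cc1` gives 5800 nM in this assay and stands within the scatter of compound 1, so the two cannot be ranked. Compound 3 `O=C(/C=C/c1ccc([N+](=O)[O-])o1)c1ccc(N2CCNCC2)cc1` has yet to be measured in this assay and keeps the rest of compound 2. From compound 2 to compound 3, the change is piperazin-1-yl in place of butyl on an aromatic carbon, para to a large group, counted in full as piperazin-1-yl in place of butyl on an aromatic carbon for this step.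

For the measured compounds named here, no measured pair differs in one place, so the data give no direct size for such a change. A small step toward a lower number is expected in this assay and would hardly go beyond the scatter. The estimated step is a 1.9-fold lower number from compound 2 to compound 3 (0.29 log units; within the scatter) on that view. For compound 3, the estimated value is 3000 nM with an expected range of 800 nM to 12000 nM in these notes.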

Compound 3, half-maximal effective concentration: 4900 nM
Estimate against measurement, compound 3: 1.6-fold (0.21 log units) below; low and high end bracket the measured number.
By their numbers in this assay, from the lowest: compounds 3, 2 and 1 (each within the scatter of the next, the first and the last beyond it).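

In this assay, for the compounds shown here, the place on the six-membered aromatic ring of carbon only, para to a large group, takes piperazin-1-yl in place of butyl with a 1.2-fold lower number from compound 2 to compound 3 (0.07 log units; within the scatter) and stays within the scatter, which is the first step that can be read in one place. On this single pair, a non-aromatic ring with hetero atoms and with a hydrogen-bond donor and acceptors, none of which butyl has, can enter here without a change in the read-out that exceeds the scatter, so the number at this place does not depend visibly on which of these two groups is present. No measured property of either group is at hand to account for this outcome.

On these data alone, it remains open whether any group at this place moves the number beyond the scatter, for instance a carboxylic acid, a simple dimethylamino group or a longer chain such as octyl. Also open, as far as these compounds go, is whether a substituent on the piperazine nitrogen, such as methyl or acetyl, would leave the number within the scatter of compound 3.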